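A Hydrazide Chain Replaces the Oxadiazole on the Shared Core

This account rests on a few compounds, and the source may have more. Where it says the series, first, only, none or still open, it means among the compounds named here.

Compound 1 `CCOC(=O)C1=C(C)NC(C)=C(C(=O)OCC)C1c1ccc(OCC(=O)Nc2c(C)cccc2C)cc1`: 53.9%
Compound 2 `CCOC(=O)C1=C(C)NC(C)=C(C(=O)OCC)C1c1ccc(OCC(=O)NNC(=O)c2ccccc2)cc1`: 44.9%
Compound 3 `CCOC(=O)C1=C(C)NC(C)=C(C(=O)OCC)C1c1ccc(OCc2nnc(S)o2)cc1`: 61.1%

All three were measured in a functional assay on the whole organism (strain Wistar) for inhibition, with Rattus norvegicus as the target, read by paw edema, with stated times of 30 min and 3 h, at a dose of 20 mg/kg; on this read-out higher numbers stand for more inhibition at the one dose given (going by the name of the read-out) and lower numbers for less inhibition. Compound 3 has the highest of the three numbers, yet a number 7.2 percentage points higher from compound 1 to compound 3 (within the scatter) stays within the scatter, while a number 16.2 percentage points higher from compound 2 to compound 3 (beyond the scatter) lies beyond it. Compound 4 `CCOC(=O)C1=C(C)NC(C)=C(C(=O)OCC)C1c1ccc(OCC(=O)NNC(=O)CCC(=O)O)cc1` has not been measured. The change is a group of 11 heavy atoms (5 carbon, 2 nitrogen, 4 oxygen; no ring) in place of a group of 6 heavy atoms (2 carbon, 2 nitrogen, 1 oxygen, 1 sulfur; one five-membered aromatic ring with 3 hetero atoms), on a saturated chain carbon bound to an oxygen on an aromatic ring. For the measured compounds named here, only one measured step bears on it, the one that also swaps a hydrazide-type chain for the oxadiazole. Because a number 16.2 percentage points higher from compound 2 to compound 3 (beyond the scatter) involved the only other such chain, compound 4 is expected to move downward by a comparable amount, a number 14.1 percentage points lower from compound 3 to compound 4 (beyond the scatter). Compound 4 is thus estimated at 47%, with a range from 35% to 59%.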

Compound 4, a percentage reported as inhibition, in the whole organism at one dose (the size of the read-out at that dose, not a potency): 56.9%
Beside the measured number, compound 4's estimate is 9.9 percentage points below it; the range from low to high includes it.
By their numbers in this assay, from the lowest: compounds 2, 1, 4 and 3 (each within the scatter of the next, the first and the last beyond it).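

On the saturated chain carbon bound to an oxygen on an aromatic ring, the 5-sulfanyl-1,3,4-oxadiazol-2-yl ring can give way to an open chain without a clear loss in this assay: a number 4.2 percentage points lower from compound 3 to compound 4 (within the scatter). A hydrazide-type chain does not fix the number either, since 2-carboxyethyl in place of phenyl on a carbonyl carbon gives a number 12 percentage points higher from compound 2 to compound 4 (beyond the scatter), while the change on the amide-type nitrogen gives only a number 3 percentage points higher from compound 1 to compound 4 (within the scatter). Nothing available explains these steps. On these data alone, whether an amine or a longer chain in place of 2-carboxyethyl would keep this level remains open.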